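From Benzyl to tert-Butyl on a Fluorinated Nitrone

The compounds below may be only part of what the source reports. "The series", "measured", "known", "first", "only" and "open" are said of these compounds alone.

Two nitrones built on a shared core have so far been tested in a functional assay on PC-3 cells (Homo sapiens) for inhibition, read by MTT assay, with a stated time of 24 h; a lower number here means a stronger inhibitor, a higher number a weaker inhibitor. Compound 1 `CCCCCCCCCCn1cc(/C=[N+](\[O-])Cc2ccccc2)nn1` carries a long alkyl chain on the core; in this assay compound 1 returns only a limit, > 100000 nM (the limit of > 100000 nM in this assay, at which 1 of the 2 values shown sits). Among the compounds with values here, compound 2 `[O-]/[N+](=C\c1cn(CCC(F)(F)C(F)(F)C(F)(F)C(F)(F)C(F)(F)C(F)(F)C(F)(F)C(F)(F)F)nn1)Cc1ccccc1` carries a long fluorinated chain in its place, and in this assay compound 2 gives 8100 nM, the only numerical value among the compounds measured so far. The two values cannot be set against each other as a sized step.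

Compound 3 `CC(C)(C)/[N+]([O-])=C/c1cn(CCC(F)(F)C(F)(F)C(F)(F)C(F)(F)C(F)(F)C(F)(F)C(F)(F)C(F)(F)F)nn1` keeps the chain of compound 2 and changes only the group on the nitrone nitrogen: tert-butyl in place of benzyl on a double-bonded nitrogen. Within the data shown here, no measured pair in this set isolates such a change, so no comparable step is available. On the numbers shown, the exchange is expected to move this assay only modestly, near the scatter, with a slight lean towards weaker inhibition. The expected step is a 1.5-fold higher number from compound 2 to compound 3 (0.17 log units; within the scatter). Compound 3 is therefore estimated at 12000 nM in this assay, with a range from 3000 nM to 50000 nM.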

Compound 3, half-maximal inhibitory concentration: 25700 nM
Estimate against measurement, compound 3: 2.1-fold (0.33 log units) below; low and high end bracket the measured number.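

In this assay, within the data shown here, the group on the double-bonded nitrogen proves able to shift the read-out: with the long fluorinated chain held fixed, tert-butyl in place of benzyl gives a 3.2-fold higher number from compound 2 to compound 3 (0.50 log units; beyond the scatter) and this is the first sized step in the set, lying beyond the scatter. The direction is towards weaker inhibition, so at this position benzyl reads better than tert-butyl on this chain, though the change is modest and both compounds still return numerical values. The exchange removes a six-membered aromatic ring of carbon only and also shortens the group, and this single pair cannot separate those two differences, nor does any measurement shown give a property that accounts for the step.

The compounds shown leave open how other groups on this nitrogen would read, such as cyclohexyl, phenyl, or a benzyl carrying a trifluoromethyl on its ring, and so whether the aromatic ring itself is what counts. They also leave open whether the same exchange would give a step of similar size with the long alkyl chain of compound 1 on the shared core.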